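The compounds below may be only part of what the source reports. "The series", "measured", "known", "first", "only" and "open" are said of these compounds alone.

In a functional assay on NCI-H1993 cells (Homo sapiens) for inhibition, read by CCK-8 assay, with a stated time of 72 h (a higher number here means a weaker inhibitor, a lower number a stronger inhibitor), compound 1 (`CCC(c1cc2cccnc2cc1F)n1cnc2ncc(-c3cnn(C)c3)nc21`) has the entry "not determined" (no result reported) and so offers no number for comparison. Among the compounds with values here, compound 2 (`Cn1nccc1-c1cnc2ncn(Cc3ccc4ncccc4c3)c2n1`) reads 7910 nM in this assay and is the only measured point so far, which leaves it with no rank and no measured step to lean on. The next compound to be read is compound 3 (`OCCn1cc(-c2cnc3ncn(Cc4ccc5ncccc5c4)c3n2)cn1`). It carries 1-(2-hydroxyethyl)-1H-pyrazol-4-yl in place of 1-methyl-1H-pyrazol-5-yl on an aromatic carbon of the shared core (1-(2-hydroxyethyl)-1H-pyrazol-4-yl in place of 1-methyl-1H-pyrazol-5-yl on an aromatic carbon). Within the data shown here, no measured pair tests this swap, so the expectation rests on the structural change alone: a large move toward a stronger inhibitor, well beyond the scatter. The expected size is a 53-fold lower number from compound 2 to compound 3 (1.72 log units; beyond the scatter) as a working estimate. For compound 3 the estimated value in this assay is 150 nM with an expected range from 20 nM to 1500 nM around it.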

Compound 3, half-maximal inhibitory concentration: 2330 nM
Compound 3: middle estimate off by 16-fold (1.19 log units), on the low side, and the stated range ends below it.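

Placing 1-(2-hydroxyethyl)-1H-pyrazol-4-yl in place of 1-methyl-1H-pyrazol-5-yl on this aromatic carbon of the shared core gives, in this assay, a 3.4-fold lower number from compound 2 to compound 3 (0.53 log units; beyond the scatter), the first measured step at this position, and it runs toward a stronger inhibitor. The swap changes two things at once: the ring attachment, 5-yl against 4-yl, and the substituent at the 1-position, methyl against 2-hydroxyethyl, so this one step cannot be divided between them. No measurement on these compounds accounts for the step.

The compounds shown leave open how 1-methyl-1H-pyrazol-4-yl would read, a group that would separate the two changes. Also open, from the compounds shown here alone, is how the number responds when the hydroxyl of the chain gives way to an amine or a carboxylic acid, or when the chain is longer.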